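Hydroxy for methoxy on a dichlorophenyl urea in this series

A few compounds are considered here, and "the series" means these few. Any claim that something is new, unique, unknown or untested is made for them only; others in the source may bear on it.

Compound 1 `O=C(Nc1cccc(-n2cc(-c3ccncc3)c(-c3ccc(Cl)c(O)c3)n2)c1)Nc1cccc(C(F)(F)F)c1` gives in a functional assay on M14 cells (Homo sapiens) for inhibition, read by sulforhodamine B assay, with a stated time of 48 h (a higher number here means that more compound is tolerated, a lower number that less compound is tolerated), the limit > 32500 nM.
Compound 2 `COc1cc(-c2nn(-c3cccc(NC(=O)c4cccc(C(F)(F)F)c4)c3)cc2-c2ccncc2)ccc1Cl` gives the limit > 50000 nM.
Compound 3 `COc1cc(-c2nn(-c3cccc(NC(=O)Nc4ccc(Cl)c(Cl)c4)c3)cc2-c2ccncc2)ccc1Cl` gives 41200 nM.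

Among the measured compounds shown here, compound 3 holds the only number of the three; the values of compound 1 and compound 2 are limits of this assay. For the measured compounds named here, the one measured step, an at least 1.2-fold lower number from compound 2 to compound 3 (0.08 log units; that floor lies within the scatter), lies within the scatter and concerns a different part of the molecule, so no measured step bears directly on the change at hand. Compound 4 `O=C(Nc1cccc(-n2cc(-c3ccncc3)c(-c3ccc(Cl)c(O)c3)n2)c1)Nc1ccc(Cl)c(Cl)c1` differs from compound 3 by hydrogen in place of methyl on an oxygen on an aromatic ring. Going by the values given here, with no step that speaks to this change, and the step that exists so small, no step beyond the scatter is expected in this assay. Compound 4 is estimated at 45000 nM (range 20000 nM to 100000 nM), a step of a 1.1-fold higher number from compound 3 to compound 4 (0.04 log units; within the scatter) that is expected to stay within the scatter.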

Compound 4, concentration lethal to 50% of the cells: > 32500 nM
Compound 4 gave a limit, no number (the forecaster's own chance of this, stated with the estimate: 55%); the middle value is on the limit's open side.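

Compound 4 gives only a limit, so the steps to compound 4 from compound 3 and from compound 1 cannot be read: the limit of > 32500 nM in this assay, at which 2 of the 4 values shown sit.

Going by these compounds, whether methoxy to hydroxy shifts the number at all, and in which direction, stays open.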